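This account rests on a few compounds, and the source may have more. Where it says the series, first, only, none or still open, it means among the compounds named here.

Compound 3 `CN(C[C@H]1Cc2c(cccc2N2C[C@@H]3C[C@H]2CN3)CN1)[C@H]1CCCc2cccnc21` gives 36.3% in an ADME assay on microsomes from liver (Mus musculus) for metabolic stability, read by LC-MS, with a stated time of 10 min (on this read-out lower numbers stand for a less stable compound and higher numbers for a more stable compound), the lowest of the three values known here; compound 1 `CN(C[C@H]1Cc2c(cccc2N2CCN(Cc3ccccn3)CC2)CN1)[C@H]1CCCc2cccnc21` at 40.4% sits within the scatter of it, while compound 2 `C[C@@H]1CN(c2cccc3c2C[C@H](CN(C)[C@H]2CCCc4cccnc42)NC3)C[C@H](C)N1` at 85.6% stands well higher. Compound 4 `CN(C[C@H]1Cc2c(cccc2N2CCN(C3COC3)CC2)CN1)[C@H]1CCCc2cccnc21` differs from compound 3 by a group of 10 heavy atoms (7 carbon, 2 nitrogen, 1 oxygen; one four-membered non-aromatic ring with 1 hetero atom, one six-membered non-aromatic ring with 2 hetero atoms) in place of a group of 7 heavy atoms (5 carbon, 2 nitrogen; 2 five-membered non-aromatic rings with 1 hetero atom each), on an aromatic carbon. Within the data shown here, the one measured step that bears on this is a number 49.3 percentage points lower from compound 2 to compound 3 (beyond the scatter), where a six-membered ring with two hetero atoms gave way to the bicyclic group; compound 4 reverses that kind of exchange, yet compound 1 also carries such a six-membered ring and gives only 40.4%. A rise of a number 18.7 percentage points higher from compound 3 to compound 4 (beyond the scatter) in this assay is therefore expected. Compound 4 is estimated at 55%, within 30% to 80%.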

Compound 4, percent of the compound remaining: 50.8%
For compound 4 the middle estimate is 4.2 percentage points above the measured one; the measured number falls inside the stated range.
By their numbers in this assay, from the lowest: compounds 3 and 1 (each within the scatter of the next); then compound 4; then compound 2.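

In this assay, placing 4-(oxetan-3-yl)piperazin-1-yl on this aromatic carbon gives a number 14.5 percentage points higher from compound 3 to compound 4 (beyond the scatter). On the amine nitrogen in the ring, oxetan-3-yl in place of (pyridin-2-yl)methyl gives a number 10.4 percentage points higher from compound 1 to compound 4 (beyond the scatter), so the group on that nitrogen shifts the number. Even so, 4-(oxetan-3-yl)piperazin-1-yl in place of 3,5-dimethylpiperazin-1-yl gives a number 34.8 percentage points lower from compound 2 to compound 4 (beyond the scatter), and neither group on that nitrogen reaches the dimethyl compound.

As far as these compounds go, how a methyl or an acetyl group on that nitrogen would compare remains open. Nothing available explains these differences.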